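The source may report more compounds than this note shows. Statements on the series, on what has been measured and on what is new or still open speak of the compounds shown alone.

Working notes on the series. In a functional assay on MCF7 cells (Homo sapiens) for inhibition, read by MTT assay, with a stated time of 48 h (a lower number here means a stronger inhibitor, a higher number a weaker inhibitor), compound 1 (`O=C(CC(c1ccc(Cl)cc1)C(C(=O)Nc1ccccn1)C(=O)Nc1ccccn1)c1ccccc1`) gives 19100 nM and compound 3 (`O=C(CC(c1ccc(Cl)cc1)C(C(=O)Nc1ccccn1)C(=O)Nc1ccccn1)c1ccc2ccccc2c1`) gives 50000 nM as its value. In this assay compound 2 (`O=C(CC(c1cccs1)C(C(=O)Nc1ccccn1)C(=O)Nc1ccccn1)c1ccccc1`) is recorded as "not active" (no number reported) with no single number, so it offers no numerical starting point for a step.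

The next compound is compound 4 (`COc1ccc(C(CC(=O)c2ccccc2)C(C(=O)Nc2ccccn2)C(=O)Nc2ccccn2)cc1`), and the change is 4-methoxyphenyl in place of thiophen-2-yl on a saturated chain carbon bound to two saturated chain carbons with 4-methoxyphenyl in place of thiophen-2-yl on a saturated chain carbon bound to two saturated chain carbons. Within the data shown here, the one measured step, a 2.6-fold higher number from compound 1 to compound 3 (0.42 log units; beyond the scatter) on a carbonyl carbon, is modest and lies at a different place, so it gives no direct size for this change. The closest reference is compound 1 at 19100 nM with another group on the same saturated chain carbon. The expectation in this assay is therefore a move from no number to a weak measurable value, though a further not-active result remains possible. For compound 4 the estimated value is 30000 nM with an expected range from 10000 nM to 100000 nM in this series.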

Compound 4, half-maximal inhibitory concentration: 48300 nM
Beside the measured number, compound 4's estimate is 1.6-fold (0.21 log units) below it; measured number inside the range.
By their numbers in this assay, from the lowest: compound 1; then compounds 4 and 3 (each within the scatter of the next).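

In this assay, among these compounds, compound 4 returns a number at the saturated chain carbon bound to two saturated chain carbons, whereas compound 2, with thiophen-2-yl in that place, is recorded as not active and so gives no step that can be read. Among the compounds shown here, the first measured step at this place is a 2.5-fold higher number from compound 1 to compound 4 (0.40 log units; beyond the scatter) and comes from methoxy in place of chloro on an aromatic carbon, so changing this substituent alters the number only modestly, although the difference lies beyond the scatter. No measured evidence on the cause of this step is available.

On these data alone, it remains open whether this step would hold with naphthalen-2-yl in place of phenyl on the carbonyl carbon. Also open, as far as these compounds go, is how a dimethylamino group or a carboxylic acid in place of chloro on that aromatic carbon would read.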